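The source may report more compounds than this note shows. Statements on the series, on what has been measured and on what is new or still open speak of the compounds shown alone.

Of the compounds shown here, three of one shared core have been tested in a functional assay on the whole organism (strain albino) for inhibition, with Rattus norvegicus as the target, read by paw edema, with a stated time of 4 h, at a dose of 0.28 mmol/kg by the oral route; a lower number here means less inhibition, a higher number more inhibition at the dose given (going by the name of the read-out). Compound 1 `CCn1c(SCC(=O)c2ccccc2)nnc1-c1ccc(OC)cc1` gives 70%. Compound 2 `COc1ccc(-c2nnc(SCC(=O)c3ccccc3)n2-c2ccccc2)cc1OC` gives 65%. Compound 3 `C=CCn1c(SCC(=O)c2ccccc2)nnc1-c1ccc(OC)cc1` gives 67%. Where compound 3 stands is therefore simple: its number sits between those of compound 1 and compound 2, and all three lie within the usual scatter of one another, so none can be called stronger or weaker than the rest.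

Compound 4 `COc1ccc(-c2nnc(SCC(=O)c3ccccc3)n2-c2ccccc2)cc1` has not yet been measured. Against compound 3 the change is phenyl in place of allyl on an aromatic nitrogen. Within the data shown here, only one measured step touches this nitrogen: a number 3 percentage points lower from compound 1 to compound 3 (within the scatter), a change that stayed within the scatter. Compound 2 also carries a phenyl on that nitrogen and gives 65%, a number close to that of compound 3. On this basis no step beyond the scatter is expected; compound 4 is estimated at 66%, with a range from 55% to 77%, which means an expected step of a number 1 percentage points lower from compound 3 to compound 4 (within the scatter).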

Compound 4, a percentage reported as inhibition, in the whole organism at one dose (the size of the read-out at that dose, not a potency): 68%
Estimate against measurement, compound 4: 2 percentage points below, and the stated range covers the measured number.
By their numbers in this assay, from the lowest: compounds 2, 3, 4 and 1 (each within the scatter of the next).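

In this assay, phenyl on the aromatic nitrogen can now be set directly against two smaller groups: phenyl in place of allyl gives a number 1 percentage points higher from compound 3 to compound 4 (within the scatter), and phenyl in place of ethyl gives a number 2 percentage points lower from compound 1 to compound 4 (within the scatter), so this nitrogen carries a six-membered aromatic ring with no change that can be told from the scatter. The new compound also isolates a second place, the methoxy on the aromatic ring, where hydrogen in place of methoxy gives a number 3 percentage points higher from compound 2 to compound 4 (within the scatter), again no real difference. No measurement here explains why these changes leave the read-out so flat.

Open, on these data alone, is whether any group on this nitrogen, such as an amine or a carboxylic acid on a longer chain, would move the number beyond the scatter. A single dose also leaves open how these compounds compare in potency.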